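A few compounds are considered here, and "the series" means these few. Any claim that something is new, unique, unknown or untested is made for them only; others in the source may bear on it.

Compound 1 `C#CCNC1CCc2c(SCCc3cccc(Br)c3)cccc21` gives 620 nM in an ADME assay on isolated protein for inhibition of Amine oxidase [flavin-containing] B (Homo sapiens); a lower number here means a stronger inhibitor, a higher number a weaker inhibitor. Compound 2 `C#CCNC1CCc2c(SCCc3ccc(F)c(F)c3)cccc21` gives "not determined" (no result reported) in this assay. Compound 3 `C#CCNC1CCc2c(SCCc3cccc(OC)c3)cccc21` gives 3820 nM in this assay.

These three share one core and differ only in the aromatic group that hangs from the chain. In this assay compound 1 gives 620 nM and compound 3 gives 3820 nM; for compound 2 the entry is "not determined" (no result reported). Compound 3 thus stands at the weaker end of the two numbers, separated from compound 1 by a 6.2-fold higher number from compound 1 to compound 3 (0.79 log units; beyond the scatter). The next compound, compound 4 `C#CCNC1CCc2c(SCCc3ccc(OC)cc3)cccc21`, keeps every atom of compound 3 and alters only the methoxyphenyl group: 4-methoxyphenyl in place of 3-methoxyphenyl on a saturated chain carbon, two bonds along the chain from a sulfur. Among the measured compounds shown here, no measured pair shows this kind of rearrangement within the ring; the only measured step, a 6.2-fold higher number from compound 1 to compound 3 (0.79 log units; beyond the scatter), exchanges one group for a different one and is modest in size. With nothing to point to a direction, the expected step is a 1.2-fold lower number from compound 3 to compound 4 (0.08 log units; within the scatter), none beyond the scatter. Compound 4 is therefore expected to give 3200 nM in this assay, within a range from 1000 nM to 10000 nM.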

Compound 4, half-maximal inhibitory concentration: 4590 nM
For compound 4 the middle estimate is 1.4-fold (0.16 log units) below the measured one; the range from low to high includes it.
By their numbers in this assay, from the lowest: compound 1; then compounds 3 and 4 (each within the scatter of the next).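

Compounds 3 and 4 give the first view of a rearrangement within the ring: 4-methoxyphenyl in place of 3-methoxyphenyl gives a 1.2-fold higher number from compound 3 to compound 4 (0.08 log units; within the scatter) in this assay, so the two methoxy compounds cannot be told apart. Replacing the 3-bromophenyl group with 4-methoxyphenyl gives a 7.4-fold higher number from compound 1 to compound 4 (0.87 log units; beyond the scatter), so compound 1 stays separate from both methoxy compounds, wherever the methoxy group sits among these two ring placements. Nothing available here explains why these groups give these numbers.

In the compounds shown, the bromo group appears in only one ring placement, so it remains open whether 4-bromophenyl would match 3-bromophenyl or fall with the methoxy compounds. Also open, as far as these compounds go, is what a nitrile on the ring, or a longer chain to the ring, would do.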